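The source may report more compounds than this note shows. Statements on the series, on what has been measured and on what is new or still open speak of the compounds shown alone.

Measured in a functional assay on HOP-62 cells (Homo sapiens) for inhibition, read by sulforhodamine B assay; on this read-out higher numbers stand for weaker inhibition of growth and lower numbers for stronger inhibition of growth:
- compound 1 `Cc1ccc2[nH]c(-c3ccc(-c4ccc(-c5cccc(Cl)c5)cc4)cc3)nc2c1` gives 2740 nM
- compound 2 `FC(F)(F)Oc1ccc(-c2ccc(-c3ccc(-c4nc5ccccc5[nH]4)cc3)cc2)cc1` gives 100000 nM
- compound 3 `Oc1cccc2[nH]c(-c3ccc(-c4ccc(-c5ccc(OC(F)(F)F)cc5)cc4)cc3)nc12` gives 2270 nM

Compound 3 sits at the low, more growth-inhibiting end of this small set. Its value lies within the usual scatter of that of compound 1, and both values are far lower than that of compound 2.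

The next compound is compound 4 `COc1ccc(-c2ccc(-c3ccc(-c4nc5c(O)cccc5[nH]4)cc3)cc2)cc1OC`. It keeps the hydroxy of compound 3 and changes the group at the far end of the molecule: 3,4-dimethoxyphenyl in place of 4-(trifluoromethoxy)phenyl on an aromatic carbon. In words, 3,4-dimethoxyphenyl comes in place of 4-(trifluoromethoxy)phenyl on an aromatic carbon.

For the measured compounds named here, the only measured step is large: a 44-fold lower number from compound 2 to compound 3 (1.64 log units; beyond the scatter). It shows what adding the hydroxy did in one pair, and compound 4 retains that hydroxy. Going by the values given here, no measured step swaps the far-end group alone, so the data give no direct guide to this change. Compound 1 has neither that hydroxy nor the 4-(trifluoromethoxy)phenyl group, yet compound 1 still gives 2740 nM.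

In this assay, among the compounds with values here, no step clearly beyond the scatter is therefore expected, with a wide margin of doubt in either direction. The estimated step is a 1.3-fold higher number from compound 3 to compound 4 (0.12 log units; within the scatter). For compound 4 the expected value is 3000 nM, within an estimated range of 1000 nM to 12000 nM.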

Compound 4, concentration for 50% growth inhibition: 2210 nM
Compound 4: middle estimate off by 1.4-fold (0.13 log units), on the high side; the measured number falls inside the stated range.
By their numbers in this assay, from the lowest: compounds 4, 3 and 1 (each within the scatter of the next); then compound 2.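

In this assay, for the compounds shown here, replacing 4-(trifluoromethoxy)phenyl with 3,4-dimethoxyphenyl gives a 1.0-fold lower number from compound 3 to compound 4 (0.01 log units; within the scatter), the first direct reading of a change at this position, and the two compounds cannot be told apart. With the hydroxy kept, this position therefore accepts either group without a clear shift in growth inhibition, even though the entering group has no fluorine and has more oxygen and more hydrogen-bond acceptors than the group it replaces. No supporting measurement is available to explain why the two groups give such closely matched results.

Going by these compounds, the large step seen on adding the hydroxy, a 44-fold lower number from compound 2 to compound 3 (1.64 log units; beyond the scatter), comes from a single pair carrying 4-(trifluoromethoxy)phenyl, so it remains open whether the hydroxy would matter as much alongside 3,4-dimethoxyphenyl. On these data alone, it is also open whether this position would accept a very different group, such as a phenyl ring carrying an amine or a carboxylic acid, as readily as it accepts these two.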